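Swapping a Methoxy for Ethyl on the Amino Side Chain

The source may hold more compounds than are shown below. What is called first, only, known or untested is meant among the compounds shown, and "the series" means these compounds.

Compound 1, `Cc1nc(N2CCCCC2)c2nnn(-c3ccc(C(C)C)cc3Br)c2n1`, gives 46 nM in an in vitro assay on 293-EBNA cells for binding affinity to corticotropin-releasing factor receptor 1 (Homo sapiens); on this read-out lower numbers stand for stronger inhibition and higher numbers for weaker inhibition.
Compound 2, `CCN(CC)c1nc(C)nc2c1nnn2-c1ccc(C(C)C)cc1Br`, gives 25.3 nM in this assay.
Compound 3, `COCCNc1nc(C)nc2c1nnn2-c1ccc(C(C)C)cc1Br`, gives 242 nM in this assay.

All three share the same core and differ only in the amino group on one aromatic carbon. Compound 3, the only one with a hydrogen on that nitrogen, carries the highest number of the three in this assay. Its nearest neighbour is compound 1, with a 5.3-fold higher number from compound 1 to compound 3 (0.72 log units; beyond the scatter), and its furthest is compound 2, with a 9.6-fold higher number from compound 2 to compound 3 (0.98 log units; beyond the scatter). The two fully substituted amines sit close together: a 1.8-fold lower number from compound 1 to compound 2 (0.26 log units; within the scatter).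

Compound 4, `CCCCNc1nc(C)nc2c1nnn2-c1ccc(C(C)C)cc1Br`, differs from compound 3 in one place: ethyl in place of methoxy on a saturated chain carbon, two bonds along the chain from a nitrogen on an aromatic ring. Among the compounds with values here, none of the measured steps makes a change of this kind; each of them exchanges the whole amino group. Whether the higher number of compound 3 goes with its chain or with the hydrogen on its nitrogen is not settled by these three compounds, since compound 4 keeps that hydrogen. A small lowering in this assay is expected, though it may stay within the scatter. The expected step is a 1.6-fold lower number from compound 3 to compound 4 (0.21 log units; within the scatter). Compound 4 is therefore expected to give about 150 nM, within a range of 50 nM to 500 nM.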

Compound 4, inhibition constant: 69.6 nM
For compound 4 the middle estimate is 2.2-fold (0.33 log units) above the measured one; the measured number falls inside the stated range.
By their numbers in this assay, from the lowest: compounds 2, 1 and 4 (each within the scatter of the next, the first and the last beyond it); then compound 3.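

In this assay, within the data shown here, the change of methoxy to ethyl on a saturated chain carbon, two bonds along the chain from a nitrogen on an aromatic ring, gives a 3.5-fold lower number from compound 3 to compound 4 (0.54 log units; beyond the scatter), so the chain alone can move the number beyond the scatter even with the hydrogen on that nitrogen kept in place, something the earlier steps could not separate, since each of them exchanged the whole amino group. That hydrogen does not by itself go with a number as high as that of compound 3: butylamino in place of piperidin-1-yl gives a 1.5-fold higher number from compound 1 to compound 4 (0.18 log units; within the scatter), which stays within the scatter, whereas butylamino in place of diethylamino gives a 2.8-fold higher number from compound 2 to compound 4 (0.44 log units; beyond the scatter), which goes beyond it, so compound 2 keeps a real lead over compound 4. No measurement in hand says why the chain with the oxygen atom and the all-carbon chain differ.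

Still open, from the compounds shown here alone, is how this place responds to other groups, such as a hydroxyl in place of the methoxy or ethyl, or a longer chain such as hexyl in place of butyl. Also open, going by these compounds, is whether the same exchange would give a step of similar size on a fully substituted amine, for example bis(2-methoxyethyl)amino set against dibutylamino.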